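This account rests on a few compounds, and the source may have more. Where it says the series, first, only, none or still open, it means among the compounds named here.

Working notes on the series. The shared core of compound 1 `CCCC(=O)N1CCC(NS(=O)(=O)c2ccc(NC(=O)c3ccccc3)c3ccccc23)CC1` carries a benzamide; in an in vitro functional assay on CHO/Galpha16 cells for antagonist activity at C-C chemokine receptor type 8 (Homo sapiens), read by FLIPR (a higher number here means a weaker inhibitor, a lower number a stronger inhibitor), compound 1 gives 12.5 nM. Compound 2 `CCCC(=O)N1CCC(NS(=O)(=O)c2ccc(NC(=O)c3ccc(F)cc3)c3ccccc23)CC1` gives 59.5 nM, and compound 3 `CCCC(=O)N1CCC(NS(=O)(=O)c2ccc(NC(=O)c3ccc(C(C)(C)C)cc3)c3ccccc23)CC1` gives 6.9 nM, the lowest of the three numbers, although the step of a 1.8-fold lower number from compound 1 to compound 3 (0.26 log units; within the scatter) lies within the scatter. The steps of a 4.8-fold higher number from compound 1 to compound 2 (0.68 log units; beyond the scatter) and an 8.6-fold lower number from compound 2 to compound 3 (0.94 log units; beyond the scatter) show that a change on this aromatic ring can move the number. Compound 4 `CCCC(=O)N1CCC(NS(=O)(=O)c2ccc(NC(=O)c3cc(C)nc(Cl)c3)c3ccccc23)CC1` differs from compound 3 by 2-chloro-6-methylpyridin-4-yl in place of 4-(tert-butyl)phenyl on a carbonyl carbon. Going by the values given here, no measured step covers a heteroaryl here; the bearing steps only show that a small halogen on that ring raised the number. Compound 4 is therefore expected to sit somewhat higher, with the step of a 2.6-fold higher number from compound 3 to compound 4 (0.42 log units; beyond the scatter) judged modest, at an estimated 18 nM in the range 5 nM to 70 nM.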

Compound 4, half-maximal inhibitory concentration: 43.9 nM
Estimate against measurement, compound 4: 2.4-fold (0.39 log units) below; measured number inside the range.
By their numbers in this assay, from the lowest: compounds 3 and 1 (each within the scatter of the next); then compounds 4 and 2 (each within the scatter of the next).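

In this assay, the step to a ring with a nitrogen atom on this carbonyl carbon is not neutral against every comparator: a 6.4-fold higher number from compound 3 to compound 4 (0.80 log units; beyond the scatter) and a 3.5-fold higher number from compound 1 to compound 4 (0.55 log units; beyond the scatter) lie beyond the scatter, whereas a 1.4-fold lower number from compound 2 to compound 4 (0.13 log units; within the scatter) lies within it. The 2-chloro-6-methylpyridin-4-yl group therefore cannot be told apart from 4-fluorophenyl here, and it offers no gain over phenyl. Nothing available here bears on why the number moves.

The compounds shown do not separate the contributions of the ring nitrogen, the chlorine and the methyl. From the compounds shown here alone, it also remains open how an amine or a carboxylic acid on this ring would read.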